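This account rests on a few compounds, and the source may have more. Where it says the series, first, only, none or still open, it means among the compounds named here.

Compound 1 `O=c1cc(CSC(=S)N2CCCC2)oc2cc(Cl)ccc12` is the reference point in a functional assay on HeLa cells (Homo sapiens) for antiproliferative activity, read by MTT assay, with a stated time of 72 h; on this read-out higher numbers stand for weaker inhibition and lower numbers for stronger inhibition. In this assay compound 1 gives > 40000 nM, which is a limit of the assay and not a number (the limit of > 40000 nM in this assay, at which 1 of the 3 values shown sits). Compound 2 `O=c1cc(CSC(=S)N2CCOCC2)oc2cc(Cl)ccc12` carries morpholin-4-yl in place of pyrrolidin-1-yl on a thiocarbonyl carbon; in this assay compound 2 gives 33300 nM, and the step is an at least 1.2-fold lower number from compound 1 to compound 2 (0.07 log units; that floor lies within the scatter). Compound 3 `O=c1c(Cl)c(CSC(=S)N2CCCC2)oc2ccccc12` has the same atoms as compound 1 joined differently; the difference between the two cores is not broken down here. In this assay compound 3 gives 700 nM, the lowest number among the measured compounds. Compound 4 `O=c1c(Cl)c(CSC(=S)N2CCOCC2)oc2ccccc12` carries the same change as from compound 1 to compound 2, (morpholin-4-yl in place of pyrrolidin-1-yl on a thiocarbonyl carbon), at the same place. Because the earlier step of an at least 1.2-fold lower number from compound 1 to compound 2 (0.07 log units; that floor lies within the scatter) lay within the scatter, the step is expected to be small, a 1.2-fold lower number from compound 3 to compound 4 (0.07 log units; within the scatter). Compound 4 is estimated at 600 nM, between 250 nM and 1500 nM.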

Compound 4, half-maximal inhibitory concentration: 4500 nM
Estimate against measurement, compound 4: 7.5-fold (0.88 log units) below, and the stated range ends below it.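

On the core of compound 3, the change gives a 6.4-fold higher number from compound 3 to compound 4 (0.81 log units; beyond the scatter), and the replacement of pyrrolidin-1-yl by morpholin-4-yl does not carry over with one size between the two cores: the same change on two cores in this assay, an at least 1.2-fold lower number (0.07 log units; that floor lies within the scatter) from compound 1 to compound 2 and a 6.4-fold higher number (0.81 log units; beyond the scatter) from compound 3 to compound 4, at least 7.7-fold (0.88 log units) apart, beyond the scatter of two such steps

Compound 1 gives > 40000 nM, which is a limit of the assay and not a number.

The exact size of the step on the core of compound 1 stays unknown, and two cores show neither the cause of the difference nor a rule for other cores.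

Open, on these data alone, is whether piperidin-1-yl or diethylamino on a thiocarbonyl carbon would follow pyrrolidin-1-yl or morpholin-4-yl on either core. Also open, as far as these compounds go, is whether the difference between the two steps holds in other cell lines.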